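This account rests on a few compounds, and the source may have more. Where it says the series, first, only, none or still open, it means among the compounds named here.

Measured compounds in this series:

- compound 1, `CC1(Cc2ccccc2)CC(S(=O)(=O)c2ccccc2F)=C(c2ccc(/C(N)=N\O)cc2)O1`; in an ADME assay on HepG2 cells (Homo sapiens) for cytotoxicity, read by MTT assay, with a stated time of 72 h (on this read-out lower numbers stand for higher toxicity in this test and higher numbers for lower toxicity in this test), compound 1 gives 61700 nM
- compound 2, `N/C(=N/O)c1ccc(C2=C(S(=O)(=O)c3ccc(F)cc3)CC(c3ccccc3)(c3ccccc3)O2)cc1`; compound 2 gives 19200 nM
- compound 3, `CC1(c2ccc(-c3cccc([N+](=O)[O-])c3)cc2)CC(S(=O)(=O)c2ccc(F)cc2)=C(c2ccc(/C(N)=N\O)cc2)O1`; compound 3 gives only a limit, > 50000 nM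

Compound 3 stands apart from the other two in that its reading is a limit of the assay and not a number, as noted in the limit of > 50000 nM in this assay, at which 1 of the 3 values shown sits. Of the two full numbers, compound 2 sits lower than compound 1, and the gap between them is wider than the usual scatter. Nothing beyond these three values is known for this series.

The next compound to be read is compound 4, `COc1cc(-c2ccc(C3(C)CC(S(=O)(=O)c4ccc(F)cc4)=C(c4ccc(/C(N)=N\O)cc4)O3)cc2)cc(OC)c1OC`. It differs from compound 3 in one place: 3,4,5-trimethoxyphenyl in place of 3-nitrophenyl on an aromatic carbon.

For the measured compounds named here, no pair of measured compounds shows a step of this kind, so there is no measured step to lean on. The expectation for this assay is a step of no more than the usual scatter, with no clear direction, which means compound 4 is expected to remain near the limit where compound 3 stands; the step of a number no higher from compound 3 to compound 4 (the limit leaves the size open) is therefore estimated as close to none. On that basis compound 4 is expected to give about 50000 nM in this assay, within the range 20000 nM to 120000 nM.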

Compound 4, half-maximal cytotoxic concentration: > 50000 nM
Compound 4 gave a limit, no number; the forecaster's own chance of this, stated with the estimate: 50%; the middle value sits exactly at the limit.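

In this assay compound 4 gives > 50000 nM, a limit and not a number. With compound 3 also at a limit, no step can be read between compound 3 and compound 4. The compounds shown leave open whether 3,4,5-trimethoxyphenyl in place of 3-nitrophenyl on an aromatic carbon shifts the reading at all, and in which direction.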